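Methylsulfanyl to tert-Butyl from a Very Weak Starting Point

The source may report more compounds than this note shows. Statements on the series, on what has been measured and on what is new or still open speak of the compounds shown alone.

Measured so far:
compound 1 `CCNc1ncc(C#Cc2ccccc2)cn1`: "not active" (no number reported)
compound 2 `Cc1cccc(C#Cc2cnc(C(C)(C)C)nc2)c1`: "not active" (no number reported)
compound 3 `CSc1ncc(C#Cc2ccccc2)cn1`: 120000 nM

In an assay on HEK293 cells for positive allosteric modulation of metabotropic glutamate receptor 5 (Rattus norvegicus) (on this read-out higher numbers stand for an effect only at larger amounts of compound and lower numbers for an effect already at smaller amounts), compound 1 gives "not active" (no number reported), and compound 2 gives "not active" (no number reported). Within the data shown here, compound 3 gives 120000 nM, the only number among the three, so it stands alone with nothing measured to compare against. Compound 4 `CC(C)(C)c1ncc(C#Cc2ccccc2)cn1` differs from compound 3 by tert-butyl in place of methylsulfanyl on an aromatic carbon. Among the measured compounds shown here, no measured pair shows what this change does. Compound 2 also carries tert-butyl and shows no effect, which gives no ground to expect a gain. The step of a 1.3-fold higher number from compound 3 to compound 4 (0.10 log units; within the scatter) is expected to be none beyond the scatter, with a real chance that no number is reported at all. For compound 4 the estimate is 150000 nM, ranging from 20000 nM to 1000000 nM.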

Compound 4, half-maximal effective concentration: 247000 nM
Beside the measured number, compound 4's estimate is 1.6-fold (0.22 log units) below it; the measured number falls inside the stated range.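

Among these compounds, putting tert-butyl in place of methylsulfanyl on the aromatic carbon between two ring nitrogen atoms gives a 2.1-fold higher number from compound 3 to compound 4 (0.31 log units; beyond the scatter) in this assay and is the first measured change at this position. This larger carbon group keeps a reported number, but the effect needs more compound, not less. Nothing available explains this shift.

The compounds shown leave open whether methoxy, cyclopropyl or a plain methyl group here would lower the number. They also leave open whether any such group could lift this weak series into a useful range.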